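A Cyano Group Added to a Shared Five-Membered Ring

The source may report more compounds than this note shows. Statements on the series, on what has been measured and on what is new or still open speak of the compounds shown alone.

Of the compounds shown here, three have been tested in an assay on membranes from brain for binding affinity to Fatty-acid amide hydrolase 1 (Mus musculus), read by fluorescence, with stated times of 1 h and 30 min; a lower number here means a stronger inhibitor, a higher number a weaker inhibitor. Compound 1, `O=C(NCc1ccc(OC(c2ccccc2)c2ccccc2)cc1)n1cccn1`, sits at the assay limit, giving > 100000 nM. Compound 2, `N#Cc1cnn(C(=O)NCc2ccc(OC(c3ccccc3)c3ccccc3)cc2)c1`, differs from it by cyano in place of hydrogen on an aromatic carbon and likewise sits at the limit, giving > 100000 nM. The step between them, a step that the two limits leave unreadable from compound 1 to compound 2, cannot be read because of the limit of > 100000 nM in this assay, at which 3 of the 3 values shown sit. Compound 3, `O=C(N1CCN(C(c2ccc(OCc3ccccc3)cc2)c2ccc(OCc3ccccc3)cc2)CC1)n1cccn1`, is built on a different core; how that core differs from the core of compound 1 is not broken down here. In this assay compound 3 also sits at the limit, giving > 100000 nM. Among the compounds with values here, compound 4, `N#Cc1cnn(C(=O)N2CCN(C(c3ccc(OCc4ccccc4)cc3)c3ccc(OCc4ccccc4)cc3)CC2)c1`, has not yet been measured; it carries the same change as the one from compound 1 to compound 2, namely (cyano in place of hydrogen on an aromatic carbon), on the core of compound 3. Within the data shown here, with the one earlier instance of this change resting on (the limit of > 100000 nM in this assay, at which 3 of the 3 values shown sit), the step from compound 3 to compound 4 in this assay is expected to be a number no higher from compound 3 to compound 4 (the limit leaves the size open). Compound 4 is therefore estimated at 100000 nM, within a wide range from 10000 nM to 300000 nM, and the measurement is expected most likely to return only a limit again.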

Compound 4, half-maximal inhibitory concentration: 790000 nM
Estimate against measurement, compound 4: 7.9-fold (0.90 log units) below, and the stated range ends below it.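

In this assay no size can be given for the change from hydrogen to cyano between compound 3 and compound 4, because compound 3 gives only a limit, not a number: the limit of > 100000 nM in this assay, at which 3 of the 4 values shown sit.

The compounds shown leave open whether adding the cyano group strengthens or weakens inhibition on either core.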